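A few compounds are considered here, and "the series" means these few. Any claim that something is new, unique, unknown or untested is made for them only; others in the source may bear on it.

Measured so far in an ADME assay on MT4 cells (Homo sapiens) for cytotoxicity, read by MTT assay, with a stated time of 5 days; a higher number here means that more compound is tolerated, a lower number that less compound is tolerated:

- Compound 1 (`COc1cc2nc(SCC(=O)Nc3ccc([N+](=O)[O-])cc3)nc(Nc3c(C)cc(/C=C/C#N)cc3C)c2cc1OC`) gives > 219000 nM, which is a limit of the assay and not a number.
- Compound 2 (`COc1cc2nc([S+]([O-])CC(=O)Nc3ccc([N+](=O)[O-])cc3)nc(Nc3c(Cl)cc(/C=C/C#N)cc3Cl)c2cc1OC`) gives 92800 nM 
- Compound 3 (`COc1cc2nc([S+]([O-])CC(=O)Nc3cccc(F)c3)nc(Nc3c(Cl)cc(/C=C/C#N)cc3Cl)c2cc1OC`) gives 9550 nM 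

Of the two true numbers in this assay, the lower belongs to compound 3, and compound 2 stands above it. The next compound, compound 4 (`COc1cc2nc([S+]([O-])CC(=O)Nc3cccc(S(N)(=O)=O)c3)nc(Nc3c(Cl)cc(/C=C/C#N)cc3Cl)c2cc1OC`), is the same as compound 3 except at one place: sulfamoyl in place of fluoro on an aromatic carbon. Put simply, sulfamoyl takes the place of fluoro on an aromatic carbon, meta to a large group.

Within the data shown here, only one measured step changes the group on this amide-type nitrogen: a 9.7-fold lower number from compound 2 to compound 3 (0.99 log units; beyond the scatter). It shows that a swap in this part of the molecule can move the number well beyond the scatter, although it involved a different incoming group. Among the measured compounds shown here, with compound 2 at 92800 nM as the only higher true number, a moderate rise is expected rather than a fall, and this guidance is weak. The expected change is a 2.6-fold higher number from compound 3 to compound 4 (0.42 log units; beyond the scatter), and it is only a rough estimate. For compound 4 the estimated value is 25000 nM, with an expected range from 7000 nM to 90000 nM.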

Compound 4, half-maximal cytotoxic concentration: 67800 nM
Beside the measured number, compound 4's estimate is 2.7-fold (0.43 log units) below it; the range from low to high includes it.
By their numbers in this assay, from the lowest: compound 3; then compounds 4 and 2 (each within the scatter of the next). At a limit, above all of these: compound 1.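

In this assay, among these compounds, replacing fluoro with sulfamoyl on the same aromatic carbon gives a 7.1-fold higher number from compound 3 to compound 4 (0.85 log units; beyond the scatter), so a change of this single group on the ring can move the number beyond the scatter, here upward, whereas the only earlier step on this part of the molecule, a 9.7-fold lower number from compound 2 to compound 3 (0.99 log units; beyond the scatter), ran downward. The second new comparison, a 1.4-fold lower number from compound 2 to compound 4 (0.14 log units; within the scatter), shows that 3-sulfamoylphenyl and 4-nitrophenyl on the amide-type nitrogen give numbers that cannot be told apart, while the 3-fluorophenyl of compound 3 stands apart from both, beyond the scatter. Nothing among the measurements shown accounts for why fluoro and sulfamoyl differ in this way.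

The compounds shown leave open whether the higher number is particular to sulfamoyl or would also appear with other groups on this aromatic carbon, such as an amine, a carboxylic acid or methylsulfonyl. They also leave open where a plain phenyl, with only hydrogen at this place, would fall relative to the 3-fluorophenyl and 3-sulfamoylphenyl compounds.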